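Acetyl in Place of Hydroxy Hydrogen: Compound 1 to Compound 4

This account rests on a few compounds, and the source may have more. Where it says the series, first, only, none or still open, it means among the compounds named here.

Of the compounds shown here, three that share a core have been measured in a functional assay for inhibition, with Rattus norvegicus as the target; on this read-out lower numbers stand for stronger inhibition and higher numbers for weaker inhibition. Compound 1, `CNc1nc(Cl)nc2c1ncn2[C@H]1CC(O)[C@]2(COP(=O)(O)O)CC12`, gives 33000 nM, the highest of the three numbers. Compound 3, `CNc1nc(Cl)nc2c1ncn2CC(COC(=O)c1ccccc1)COC(=O)c1ccccc1`, gives 5100 nM and is the nearest to compound 1, with a gap that lies beyond the scatter. Compound 2, `CNc1nc(Cl)nc2c1ncn2CC(COC(=O)Nc1ccccc1)COP(=O)(O)O`, gives 2500 nM and is the furthest from compound 1, again beyond the scatter. Compound 1 therefore stands as the weakest inhibitor of the three. Among the measured compounds shown here, compounds 2 and 3 differ from compound 1 in several places at once, so no single-point step between measured compounds is available.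

Compound 4, `CNc1nc(Cl)nc2c1ncn2[C@H]1CC(OC(C)=O)[C@]2(COP(=O)(O)O)CC12`, differs from compound 1 in one place: acetyl in place of hydrogen on an oxygen on a saturated carbon. Nothing measured here shows the effect of this change, so the expectation rests on the change alone and on the footing of compound 1 at 33000 nM in this assay.

Compound 4 is expected to stay close to compound 1, with the step from compound 1 to compound 4 estimated as a 1.3-fold lower number from compound 1 to compound 4 (0.12 log units; within the scatter), a small move that may not exceed the scatter, perhaps toward a lower number. Compound 4 is thus estimated at 25000 nM in this assay, within a range of 8000 nM to 80000 nM.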

Compound 4, inhibition constant: 10000 nM
The estimate for compound 4 lay 2.5-fold (0.40 log units) above the measured number; the measured number falls inside the stated range.
By their numbers in this assay, from the lowest: compound 2; then compounds 3 and 4 (each within the scatter of the next); then compound 1.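

In this assay the change from hydroxy to acetoxy gives a 3.3-fold lower number from compound 1 to compound 4 (0.52 log units; beyond the scatter) as a modest step that lies beyond the scatter. Among the compounds shown here, this is the first single-point step, and it shows that this oxygen on a saturated carbon accepts acetyl in place of hydrogen, with the number going down rather than up, so the hydroxy hydrogen is not needed for the inhibition seen on this read-out. Nothing in the available data explains why the acetoxy compound gives the lower number.

One acetyl group cannot show whether the step comes from the acetyl group itself or from the loss of the hydroxy hydrogen, a question that a methyl ether on the same oxygen, or a longer acyl group such as propionyl or benzoyl, could help to settle. Also open, as far as these compounds go, is whether a step of this size would hold if a carboxylic acid took the place of the phosphate group on the shared core.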